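The source may hold more compounds than are shown below. What is called first, only, known or untested is meant among the compounds shown, and "the series" means these compounds.

Three compounds have been measured in a physicochemical assay for lipophilicity, read by LC-MS, in phosphate buffer, measured as octanol-water partition, with a stated time of 30 min, at pH 7.4, tested at 200 mM; on this read-out higher numbers stand for higher lipophilicity and lower numbers for lower lipophilicity:

compound 1 `Cn1c(COc2cccc(C(=O)O)c2)nc2ccc(Oc3ccc(F)cc3)nc21` gives 1.5;
compound 2 `Cc1ccc(Oc2ccc3nc(COc4cccc(C(=O)O)c4)n(C)c3n2)cc1C` gives 2.2;
compound 3 `Cn1c(COc2cccc(C(=O)O)c2)nc2ccc(Oc3cccc(Cl)n3)cc21` gives 1.2.

Compound 3 has the lowest of these three numbers, but its nearest neighbour is compound 1, whose number lies within the scatter of the method, so the two cannot be ordered with confidence; only compound 2 stands clearly apart, with a number beyond the scatter above compound 3.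

The step to be followed leads from compound 3 to compound 4 `Cn1c(COc2cccc(C(=O)O)c2)nc2ccc(Oc3ncccc3F)cc21`. The structural change is 3-fluoropyridin-2-yl in place of 6-chloropyridin-2-yl on an oxygen on an aromatic ring. Among the measured compounds shown here, the one measured step, a number 0.70 log units higher from compound 1 to compound 2 (beyond the scatter), concerns a different exchange on the same oxygen and does not match this change, so no measured step bears directly on it. Without a matching precedent, the expectation rests on the values themselves: compound 4 is expected to give 0.8 in this assay , between 0.3 and 1.3, which means an expected step of a number 0.40 log units lower from compound 3 to compound 4 (beyond the scatter).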

Compound 4, distribution coefficient: 0.6
Estimate against measurement, compound 4: 0.20 log units above; the range from low to high includes it.
By their numbers in this assay, from the lowest: compound 4; then compounds 3 and 1 (each within the scatter of the next); then compound 2.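

In this assay there is a number 0.60 log units lower from compound 3 to compound 4 (beyond the scatter) when 3-fluoropyridin-2-yl replaces 6-chloropyridin-2-yl on this oxygen, whereas the earlier exchange on such an oxygen, in a compound with a slightly different core, moved the number the other way. The two pyridine groups have the same counts of heavy atoms, hydrogen-bond donors and acceptors, and neither carries a net charge, so the read-out at this position can shift even when those counts stay the same. Nothing measured here explains the size or direction of this shift.

The exchange alters both the halogen and its place on the ring, and the compounds shown do not separate the two. They also leave open how a pyridin-2-yl group with no halogen, or one carrying an amine, would read on this oxygen.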